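A Methoxy-to-Fluoro Swap in an Antiproliferative Series

The source may report more compounds than this note shows. Statements on the series, on what has been measured and on what is new or still open speak of the compounds shown alone.

In a functional assay on MCF7 cells (Homo sapiens) for antiproliferative activity, with a stated time of 72 h (a higher number here means a weaker inhibitor, a lower number a stronger inhibitor), compound 1 `COc1cc(OCC(=O)NO)ccc1CNCCn1cnc2ccccc21` offers no exact number. Compound 1 gives > 10000 nM, which is only a limit of the assay. Within the data shown here, the one exact number so far belongs to compound 2 `O=C(COc1ccc(CNC2CC=C(c3c[nH]c4cccc(F)c34)CC2)c(F)c1)NO`, which gives 915 nM in this assay. Compound 2 also carries fluoro on an aromatic carbon, but it differs from compound 1 in more than one place, so its value cannot be credited to fluoro alone.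

Compound 3 `O=C(COc1ccc(CNCCn2cnc3ccccc32)c(F)c1)NO` changes compound 1 in one place: fluoro in place of methoxy on an aromatic carbon. This puts fluoro in place of methoxy on an aromatic carbon, ortho to a large group and meta to a (hydroxycarbamoyl)methoxy group. Among the measured compounds shown here, no measured single-place step is available as a guide. In this assay, a modest move toward stronger inhibition is expected, and compound 3 may well report only a limit too. The expected change is an at least 1.2-fold lower number from compound 1 to compound 3 (0.09 log units; that floor lies within the scatter). For compound 3 the estimated value is 8000 nM, with an expected range of 2500 nM to 20000 nM.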

Compound 3, half-maximal inhibitory concentration: 539 nM
Estimate against measurement, compound 3: 15-fold (1.17 log units) above; the whole stated range lies above it.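

In this assay, the place ortho to a large group and meta to a (hydroxycarbamoyl)methoxy group turns out to be sensitive to what it carries: fluoro in place of methoxy gives an at least 18-fold lower number from compound 1 to compound 3 (1.26 log units; beyond the scatter). Compound 3 gives 539 nM, an exact number, which shows that this single change on the core of compound 1 is enough to give a measurable value, something compound 2 could not show with its several differences. The value of compound 1 is a limit and not a number, which is why the step can be stated only as a floor and its full size stays unknown: the limit of > 10000 nM in this assay, at which 1 of the 3 values shown sits.

Among these compounds, the single pair cannot separate the effect of losing methoxy from that of gaining fluoro, and a plain hydrogen, a chloro or a hydroxyl at the same place would be needed to tell which of the two matters and how narrow the preference is. Whether the same swap carries the same weight on another core, such as that of compound 2, also stays open, as the compounds shown hold only this one step.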